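Benzylation of the Ring Nitrogen in a Cytotoxicity Series

The source may report more compounds than this note shows. Statements on the series, on what has been measured and on what is new or still open speak of the compounds shown alone.

The measured compounds:
Compound 1, `Cn1c(-c2cccc(C#N)c2)cnc1NC(=O)c1ncc[nH]1`, in a toxicity assay on THP-1 cells (Homo sapiens) for inhibition (on this read-out higher numbers stand for lower toxicity in this test and lower numbers for higher toxicity in this test), compound 1 gives > 50000 nM, a limit of the assay.
Compound 2, `COc1ccc(-c2cnc(NC(=O)CCc3ccccc3)n2C)cc1`, in this assay compound 2 gives > 100000 nM, a limit of the assay.
Compound 3, `COc1ccc(-c2cnc(NC(=O)c3ccc(F)cc3)[nH]2)cc1`, in this assay compound 3 gives > 100000 nM, a limit of the assay.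

Compound 3 stands at a limit rather than a number. Its value sits at the limit of > 100000 nM in this assay, at which 2 of the 3 values shown sit, while compound 1 sits at the limit of > 50000 nM in this assay, at which 1 of the 3 values shown sits; no numbered step between any two of the measured compounds is available, so nothing is known here about how changes in this series move the read-out.

Compound 4, `COc1ccc(-c2cnc(NC(=O)c3ccc(F)cc3)n2Cc2ccccc2)cc1`, is not yet measured. It differs from compound 3 by benzyl in place of hydrogen on an aromatic nitrogen.

Going by the values given here, with no measured step to lean on, the step from compound 3 to compound 4 is expected to be small or none beyond the scatter, and its size is estimated as a number no higher from compound 3 to compound 4 (the limit leaves the size open). Compound 4 is expected to give about 100000 nM in this assay, within a range of 30000 nM to 200000 nM, most likely again reported only as a limit.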

Compound 4, half-maximal cytotoxic concentration: > 100000 nM
Compound 4: only a limit was reported; the forecaster's own chance of this, stated with the estimate: 60%; the middle value lies on the limit itself.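

In this assay compound 3 and compound 4 both stand at the same limit, so no step can be read for benzyl in place of hydrogen on an aromatic nitrogen. The compounds shown leave open whether any change in this series moves the read-out at all.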